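Swapping methyl for cyclopropyl on a saturated ring carbon

The source may hold more compounds than are shown below. What is called first, only, known or untested is meant among the compounds shown, and "the series" means these compounds.

Measured so far in an in vitro ADME assay on microsomes (Homo sapiens) for metabolic stability; a lower number here means slower removal, a higher number faster removal of the compound:
- compound 1 `O=C(CN1C[C@H](NC(=O)c2ccc(Cl)s2)[C@@H](OCC(F)F)C1)Nc1ccc(-n2ccccc2=O)cc1F` gives 9 mL.min-1.g-1
- compound 2 `CC1CN(CC(=O)Nc2ccc(-n3ccccc3=O)cc2F)CC1NC(=O)c1ccc(Cl)s1` gives 76.3 mL.min-1.g-1

Compound 2 (76.3 mL.min-1.g-1) has the higher of the two numbers. Compound 1 (9 mL.min-1.g-1) lies below it, and the gap is beyond the usual scatter of repeat measurements. Of these two, compound 2 is therefore the one removed faster in this assay and has more room for improvement.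

Compound 3 (`O=C(CN1CC(NC(=O)c2ccc(Cl)s2)C(C2CC2)C1)Nc1ccc(-n2ccccc2=O)cc1F`) starts from compound 2 and puts cyclopropyl in place of methyl on a saturated ring carbon, two ring bonds from the ring nitrogen. The rest of the molecule stays the same. Going by the values given here, no measured pair here differs in only one place, so the data give no direct guide to the effect of this swap. The best anchor is the value of compound 2 (76.3 mL.min-1.g-1). The expected 1.2-fold higher number from compound 2 to compound 3 (0.07 log units; within the scatter) is small and slightly upward, and it probably stays within the scatter. Compound 3 is expected at 90 mL.min-1.g-1 within an estimated range of 40 mL.min-1.g-1 to 190 mL.min-1.g-1 in this measurement.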

Compound 3, intrinsic clearance in microsomes: 267 mL.min-1.g-1
Compound 3: the middle estimate sits 3.0-fold (0.47 log units) below what was measured; measured number outside the range, above it.
By their numbers in this assay, from the lowest: compound 1; then compound 2; then compound 3.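

In this assay, putting cyclopropyl in place of methyl on this saturated ring carbon gives a 3.5-fold higher number from compound 2 to compound 3 (0.54 log units; beyond the scatter) and so moves the compound toward faster removal. Going by these compounds alone, this is the first direct reading at this position, since the earlier compounds offered no pair differing in only one place, and it shows that the position is not indifferent to what it carries. The change is small on paper, from one carbon to three carbons closed into a three-membered ring, with no hydrogen-bond donors or acceptors on either group, yet the step lies beyond the usual scatter, and no measurement at hand bears on what lies behind it.

A single step cannot separate the effect of the added carbons from that of the ring itself, and an ethyl or isopropyl group at the same carbon, which adds carbons without a ring, would help to tell the two apart. Going by these compounds, it also remains open how this position would respond to a group carrying oxygen or nitrogen, such as methoxy or an amine.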